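Ring Size of the Amine and Cytotoxicity in Glioma Cells

A few compounds are considered here, and "the series" means these few. Any claim that something is new, unique, unknown or untested is made for them only; others in the source may bear on it.

Compound 1 `O=C(c1ccccc1)c1sc(N2CCCC2)nc1Br` and compound 2 `O=C(c1ccccc1)c1sc(N2CCCCC2)nc1Br` share a core and differ only in piperidin-1-yl in place of pyrrolidin-1-yl on an aromatic carbon. In a functional assay on Hs 683 cells (Homo sapiens) for cytotoxicity, read by MTT assay, with a stated time of 72 h (on this read-out higher numbers stand for weaker inhibition and lower numbers for stronger inhibition), compound 1 reaches only the assay limit, > 100000 nM, which is a limit and not a number (the limit of > 100000 nM in this assay, at which 1 of the 3 values shown sits). In this assay compound 2 gives 38000 nM. For the measured compounds named here, the step of an at least 2.6-fold lower number from compound 1 to compound 2 (0.42 log units; beyond the scatter) is the only measured instance of this exchange.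

Compound 3 `COC(=O)c1sc2nc(N3CCCC3)sc2c1C` rests on a different core; the difference between the two cores is not broken down here. In this assay compound 3 gives 91000 nM, the highest numerical value among the measured compounds, with compound 2 nearest to it.

Compound 4 `COC(=O)c1sc2nc(N3CCCCC3)sc2c1C` has not yet been measured. It relates to compound 3 through (piperidin-1-yl in place of pyrrolidin-1-yl on an aromatic carbon), the same kind of change that separates compound 1 from compound 2. The surroundings are not identical: in compound 3 the aromatic carbon is part of a fused or bridged system of two rings, whereas in compound 1 it sits two ring bonds from the ring atom that bears a bromo group and two ring bonds from the ring atom that bears a group of 8 heavy atoms.

Judged on the single precedent an at least 2.6-fold lower number from compound 1 to compound 2 (0.42 log units; beyond the scatter), the step from compound 3 to compound 4 is expected to be a 2.6-fold lower number from compound 3 to compound 4 (0.41 log units; beyond the scatter) in this assay. Compound 4 is therefore estimated at 35000 nM, expected to fall between 12000 nM and 100000 nM.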

Compound 4, half-maximal inhibitory concentration: > 100000 nM
Compound 4: only a limit was reported; the forecaster's own chance of this, stated with the estimate: 15%; at least 2.8-fold (0.45 log units) between middle value and limit.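

In this assay compound 4 is reported as > 100000 nM, which is a limit of the assay and not a number. On the core of compound 3, piperidin-1-yl in place of pyrrolidin-1-yl gives an at least 1.0-fold higher number from compound 3 to compound 4 (0.04 log units; that floor lies within the scatter), so the lower number seen on the core of compound 1 does not carry over, and the two steps differ: the same change on two cores in this assay, an at least 2.6-fold lower number (0.42 log units; beyond the scatter) from compound 1 to compound 2 and an at least 1.0-fold higher number (0.04 log units; that floor lies within the scatter) from compound 3 to compound 4, at least 2.8-fold (0.46 log units) apart, beyond the scatter of two such steps This shows that the exchange cannot be transferred from one core to the other in this series, but with a single pair on each core it shows neither why the cores part ways nor the true size of either step, since each step has one end resting on a limit: the limit of > 100000 nM in this assay, at which 2 of the 4 values shown sit.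

The compounds shown leave open how other cyclic amines, such as morpholin-4-yl, piperazin-1-yl or the larger azepan-1-yl, or an open-chain amine such as dimethylamino, would behave on either core. They also leave open whether a carboxylic acid or an amide in place of the methyl ester on the core of compound 3, or a chloro group in place of the bromo group on the core of compound 1, would change the outcome of the same exchange.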